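The source may report more compounds than this note shows. Statements on the series, on what has been measured and on what is new or still open speak of the compounds shown alone.

Of the compounds shown here, three have been tested in a functional assay for antagonist activity at transient receptor potential cation channel subfamily V member 1 (Homo sapiens), read by calcium flux; a higher number here means a weaker inhibitor, a lower number a stronger inhibitor. Compound 1 `O=C(Nc1cccc2[nH]ncc12)N[C@H]1CCOc2cc(C(F)(F)F)ccc21` gives 43 nM. Compound 2 `CC(C)(C)c1ccc2c(c1)OCCC2NC(=O)Nc1cccc2[nH]ncc12`, drawn without a configuration at its ring stereocentre, gives 43 nM. Compound 3 `CC(C)(C)c1ccc2c(c1)OCC[C@H]2NC(=O)Nc1cccc2[nH]ncc12`, the same molecule drawn with that stereocentre in the R configuration, gives 31 nM. Within the data shown here, compound 3 gives the lowest number of the three, but its gaps to compound 1 and to compound 2 both lie within the scatter, so no compound among them can be called stronger than another.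

The next compound, compound 4 `CC(C)(C)c1ccc2c(c1)OCC[C@@H]2NC(=O)Nc1cccc2[nH]ncc12`, differs from compound 3 only in configuration: the two compounds have the same atoms and bonds and differ only in configuration as drawn: 1 of 1 stereo elements differ; a stereocentre at a saturated ring carbon is drawn R in compound 3 and S in compound 4. Among the measured compounds shown here, one measured step bears on this, a 1.4-fold lower number from compound 2 to compound 3 (0.14 log units; within the scatter), which compares the compound drawn without configuration to its R form; this rests on (the fact that one of compounds 2 and 3 is drawn with a defined configuration and the other without, at the place where they differ). That step lies within the scatter, so it gives no firm reading on how far the two configurations differ, though a mixture that is no weaker than its R component leaves room for the S form to be somewhat weaker.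

For compound 4 the step of a 2.9-fold higher number from compound 3 to compound 4 (0.46 log units; beyond the scatter) is therefore expected to be a modest rise. The estimate for compound 4 in this assay is 90 nM, with a range from 30 nM to 400 nM.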

Compound 4, half-maximal inhibitory concentration: 1200 nM
For compound 4 the middle estimate is 13-fold (1.12 log units) below the measured one; the measured number lies above the stated range.
By their numbers in this assay, from the lowest: compounds 3, 1 and 2 (each within the scatter of the next); then compound 4.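

At this ring carbon the drawn configuration decides the outcome in this assay, with a 39-fold higher number from compound 3 to compound 4 (1.59 log units; beyond the scatter), a large step that can be tied to this one place: the fact that compounds 3 and 4 differ only in the configuration as drawn. The earlier step from the undefined compound to the R form could not show this, yet the undefined compound also stands far from the S form, with a 28-fold higher number from compound 2 to compound 4 (1.45 log units; beyond the scatter), and its number remains within the scatter of the R form's: the fact that one of compounds 2 and 4 is drawn with a defined configuration and the other without, at the place where they differ. The group on the aromatic ring also counts, with a 28-fold higher number from compound 1 to compound 4 (1.45 log units; beyond the scatter), a step that changes only tert-butyl in place of trifluoromethyl, so the configuration of compound 4 goes with a much lower number in compound 1, which gives 43 nM.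

It remains open how much configuration matters in the trifluoromethyl series, since the partner of compound 1 with the opposite configuration is not among the compounds shown. On these data alone, it is also open whether a chlorine atom or a methoxy group on the same aromatic carbon would follow tert-butyl or trifluoromethyl in this configuration.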